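From Nitro to Fluoro: What Happens to Cytotoxicity

A few compounds are considered here, and "the series" means these few. Any claim that something is new, unique, unknown or untested is made for them only; others in the source may bear on it.

Compound 1, `Cc1nnc(SCC(=O)N/N=c2/scc(-c3ccc(C#N)cc3)n2-c2ccccc2)s1`: < 3.9 ug/mL
Compound 2, `O=C(CSc1ncccn1)N/N=c1/scc(-c2ccc(F)cc2)n1-c1ccccc1`: > 500 ug/mL
Compound 3, `Cc1nnc(SCC(=O)N/N=c2/scc(-c3ccc([N+](=O)[O-])cc3)n2-c2ccccc2)s1`: 177 ug/mL

Of the compounds shown here, three have been measured in an ADME assay on NIH3T3 cells (Mus musculus) for cytotoxicity, read by MTT assay, with a stated time of 24 h; a lower number here means a stronger inhibitor, a higher number a weaker inhibitor. The value of compound 1 is a limit of the assay, not a number. The value of compound 2 is likewise a limit. Compound 3 is therefore the only one of the three with an actual number, and it stands alone in the middle of the range, with one compound sitting at each end as a limit.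

Among the measured compounds shown here, only one measured pair differs in a single place: an at least 45-fold higher number from compound 1 to compound 3 (1.65 log units; beyond the scatter), where nitro replaces cyano on an aromatic carbon. Because compound 1 sits at the limit of < 3.9 ug/mL in this assay, at which 1 of the 3 values shown sits, the true size of that step is known only as a minimum.

Compound 4, `Cc1nnc(SCC(=O)N/N=c2/scc(-c3ccc(F)cc3)n2-c2ccccc2)s1`, has not yet been measured. It differs from compound 3 by fluoro in place of nitro on an aromatic carbon. Compound 2 also carries fluoro on the same kind of aromatic carbon, though it differs from compound 4 in a second place as well, and its value sits at the limit of > 500 ug/mL in this assay, at which 1 of the 3 values shown sits. A weaker result than compound 3 therefore seems the more likely outcome, though the evidence is thin. Compound 4 is expected to give 300 ug/mL, within 80 ug/mL to 1000 ug/mL. That would mean an expected step of a 1.7-fold higher number from compound 3 to compound 4 (0.23 log units; within the scatter).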

Compound 4, half-maximal inhibitory concentration: 383 ug/mL
Estimate against measurement, compound 4: 1.3-fold (0.11 log units) below, and the stated range covers the measured number.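

On this aromatic carbon, with the rest of the molecule unchanged, fluoro in place of nitro moves the result in this assay only modestly (a 2.2-fold higher number from compound 3 to compound 4 (0.34 log units; beyond the scatter)). Cyano now stands apart from both nitro and fluoro, with a large step on its side (an at least 98-fold higher number from compound 1 to compound 4 (1.99 log units; beyond the scatter)) that is only a minimum, set by the limit of compound 1: the limit of < 3.9 ug/mL in this assay, at which 1 of the 4 values shown sits. The change on the sulfur says much less, with 5-methyl-1,3,4-thiadiazol-2-yl in place of pyrimidin-2-yl giving only a floor that lies within the usual scatter (an at least 1.3-fold lower number from compound 2 to compound 4 (0.11 log units; that floor lies within the scatter)), set by the limit of compound 2: the limit of > 500 ug/mL in this assay, at which 1 of the 4 values shown sits.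

As far as these compounds go, what an amine, a carboxylic acid or a longer chain on this same aromatic carbon would give remains open. Nothing here explains why the cyano compound stands apart from the nitro and fluoro compounds, and compound 1 has no actual number that would show how wide that gap really is.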